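This account rests on a few compounds, and the source may have more. Where it says the series, first, only, none or still open, it means among the compounds named here.

Of the compounds shown here, three built on one shared core have been measured in an assay on FRT-Jurkat cells for inhibition of nuclear factor NF-kappa-B complex (Homo sapiens), read by flow cytometry, with a stated time of 24 h, tested at 10 uM; a lower number here means less inhibition, a higher number more inhibition at the concentration tested (going by the name of the read-out). Compound 1, `O=C1CCC(N2C(=O)c3ccc(Nc4ccc(O)cc4)cc3C2=O)C(=O)N1`, gives 4%. Compound 2, `Cc1ccc(Nc2ccc3c(c2)C(=O)N(C2CCC(=O)NC2=O)C3=O)cc1`, gives 5%, and compound 3, `CCOC(=O)c1ccc(Nc2ccc3c(c2)C(=O)N(C2CCC(=O)NC2=O)C3=O)cc1`, gives 5%. Each pair differs in a single group: a number 1 percentage points higher from compound 1 to compound 2 (within the scatter), a number 1 percentage points higher from compound 1 to compound 3 (within the scatter), and no change at the digits printed from compound 2 to compound 3 (within the scatter). Compound 3 thus stands level with compound 2 at the digits reported, the two together carrying the highest of the three numbers, though the gap to compound 1 lies within the scatter, so no ordering among the three can be drawn.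

The next compound, compound 4, `CCCCCc1ccc(Nc2ccc3c(c2)C(=O)N(C2CCC(=O)NC2=O)C3=O)cc1`, differs from compound 3 in one place: pentyl in place of ethoxycarbonyl on an aromatic carbon. The three measured steps bear on this change, since each also swapped the group on an aromatic carbon of the shared core, and all three produced numbers that sit within the scatter of one another. Pentyl has not appeared on any measured compound, so the expectation rests only on how little the read-out has moved so far. The estimated step for compound 4 is no change at the digits printed from compound 3 to compound 4 (within the scatter), meaning no movement beyond the scatter is expected. The estimate for compound 4 is 5%, ranging from -5% to 15%.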

Compound 4, a percentage reported as inhibition, at one concentration (the size of the read-out at that concentration, not a potency): 12%
Beside the measured number, compound 4's estimate is 7 percentage points below it, and the stated range covers the measured number.
By their numbers in this assay, from the lowest: compounds 1, 2, 3 and 4 (each within the scatter of the next).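

This position on the six-membered aromatic ring, para to a large group, has now carried a saturated chain with no hydrogen-bond acceptors. Exchanging ethoxycarbonyl for pentyl keeps 5 heavy atoms but removes both oxygens, the double bond and the 2 hydrogen-bond acceptors, and in this assay this gives a number 7 percentage points higher from compound 3 to compound 4 (within the scatter) on this read-out. The other two comparisons, extending methyl by butyl to reach pentyl and replacing hydroxy with pentyl, give a number 7 percentage points higher from compound 2 to compound 4 (within the scatter) and a number 8 percentage points higher from compound 1 to compound 4 (within the scatter) as their results, so even this change of chain and atom type does not separate compound 4 from the other three compounds. No measurement is available that could explain these numbers.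

From the compounds shown here alone, whether any group at this position can move the number beyond the scatter remains open, for example a longer chain such as octyl, an amine or a carboxylic acid. Each compound also has a reading at only one concentration, so these numbers say nothing about potency.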